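The compounds below may be only part of what the source reports. "The series", "measured", "known", "first", "only" and "open" are said of these compounds alone.

Measured compounds in an assay on membranes from HEK293 cells for displacement of a labelled ligand from adenosine receptor A2b (Homo sapiens), read by scintillation counting, with a stated time of 30 min; a higher number here means a weaker inhibitor, a lower number a stronger inhibitor:
compound 1 `CC1=C(C(=O)OCC2CC2)C(c2ccoc2)NC(=O)N1` gives 426 nM
compound 2 `CC1=C(C(=O)OCC2CCC2)C(c2ccoc2)NC(=O)N1` gives 739 nM
compound 3 `CC1=C(C(=O)OCC2CC2)C(c2cccs2)NC(=O)N1` gives 1570 nM

Compound 4 `CC1=C(C(=O)OCC2CCC2)C(c2cccs2)NC(=O)N1` is not yet measured in this assay. It differs from compound 3 by cyclobutyl in place of cyclopropyl on a saturated chain carbon bound to an oxygen next to a carbonyl group. The same change has been made once before, from compound 1 to compound 2: cyclobutyl in place of cyclopropyl on a saturated chain carbon bound to an oxygen next to a carbonyl group. That step read a 1.7-fold higher number from compound 1 to compound 2 (0.24 log units; within the scatter). The two cores differ by thiophen-2-yl in place of furan-3-yl on a saturated ring carbon, a step of a 3.7-fold higher number from compound 1 to compound 3 (0.57 log units; beyond the scatter). The place of the change is described in the same words in both pairs, so the change from compound 3 to compound 4 is the same as that from compound 1 to compound 2.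

Within the data shown here, for compound 4 in this assay a step of about a 1.7-fold higher number from compound 3 to compound 4 (0.22 log units; within the scatter) is expected, resting on the single earlier step of a 1.7-fold higher number from compound 1 to compound 2 (0.24 log units; within the scatter) and on the value of compound 3, 1570 nM. The estimate for compound 4 is 2600 nM, between 1200 nM and 5500 nM.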

Compound 4, inhibition constant: 2840 nM
Compound 4: middle estimate off by 1.1-fold (0.04 log units), on the low side, and the stated range covers the measured number.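

In this assay, cyclobutyl in place of cyclopropyl gives a 1.8-fold higher number from compound 3 to compound 4 (0.26 log units; within the scatter) with thiophen-2-yl present, and this agrees with the step seen with furan-3-yl: the same change on two cores in this assay, a 1.7-fold higher number (0.24 log units; within the scatter) from compound 1 to compound 2 and a 1.8-fold higher number (0.26 log units; within the scatter) from compound 3 to compound 4, 1.0-fold (0.02 log units) apart, within the scatter of two such steps. Thiophen-2-yl in place of furan-3-yl gives a 3.8-fold higher number from compound 2 to compound 4 (0.58 log units; beyond the scatter) with cyclobutyl present, and this step also carries over: the same change on two cores in this assay, a 3.7-fold higher number (0.57 log units; beyond the scatter) from compound 1 to compound 3 and a 3.8-fold higher number (0.58 log units; beyond the scatter) from compound 2 to compound 4, 1.0-fold (0.02 log units) apart, within the scatter of two such steps. The two changes therefore combine without visible interaction across these four compounds, but this is a single set of paired steps. The cyclobutyl step lies within the scatter. It does not establish a real difference between cyclobutyl and cyclopropyl.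

Going by these compounds, it remains open whether this holds for a phenyl ring on the saturated ring carbon. The same applies to a longer chain or an amine in place of cyclobutyl.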